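Hydroxy to hydrogen on the aryl group of compound 3

The source may hold more compounds than are shown below. What is called first, only, known or untested is meant among the compounds shown, and "the series" means these compounds.

Compound 1 `Cc1cccc(NC(=O)CN2CCC(c3nccs3)CC2)c1` gives 62% in a functional assay on HEK293 cells for agonist activity at D(4) dopamine receptor (Homo sapiens), read by FLIPR; on this read-out lower numbers stand for smaller maximal responses and higher numbers for larger maximal responses. Compound 2 `Cc1cccc(NC(=O)CN2CCC(c3ccc(O)cc3)CC2)c1` gives 60% in this assay. Within the data shown here, the only step seen so far, a number 2 percentage points lower from compound 1 to compound 2 (within the scatter), shows that exchanging the group on the saturated ring carbon left the maximal response essentially unchanged. Among the measured compounds shown here, compound 2 thus stands within the usual scatter of compound 1, the only other number at hand, so neither of the two stands apart.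

Compound 3 `Cc1cccc(NC(=O)CN2CCC(c3ccccc3)CC2)c1` differs from compound 2 by hydrogen in place of hydroxy on an aromatic carbon. For the measured compounds named here, no measured step removes a hydroxy, so the step from compound 1 to compound 2 is the only point of comparison: a larger exchange at the same position moved the read-out by a number 2 percentage points lower from compound 1 to compound 2 (within the scatter), within the scatter. A smaller change on the same aryl group is therefore not expected to move the maximal response beyond the scatter.

Compound 3 is expected to give 60% in this assay, with a range from 45% to 75%. The expected step is no change at the digits printed from compound 2 to compound 3 (within the scatter).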

Compound 3, largest response reached (reported as efficacy), in percent of the reference or control that the assay uses: 37%
Compound 3: middle estimate off by 23 percentage points, on the high side, outside the stated range (below it).
By their numbers in this assay, from the lowest: compound 3; then compounds 2 and 1 (each within the scatter of the next).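

In this assay, the group on the saturated ring carbon is not interchangeable: a number 23 percentage points lower from compound 2 to compound 3 (beyond the scatter) shows that this single hydroxy on the aromatic carbon separates a response within the scatter of compound 1 from a clearly smaller one. The step of a number 25 percentage points lower from compound 1 to compound 3 (beyond the scatter) shows the same from the other side, so the flat step between the first two compounds marks two groups that happen to give matching responses, not a position that accepts any aryl group. No measurement at hand accounts for the drop on loss of the hydroxy, and the link between these groups and the response remains descriptive.

From the compounds shown here alone, whether the response depends on the hydroxy itself stays open, since an amine, a methoxy group or a fluorine on the same aromatic carbon would be needed to tell whether other groups there keep the response of compound 2. Going by these compounds, it also stays open whether another nitrogen-containing ring, such as pyridin-2-yl, would match 1,3-thiazol-2-yl without any hydroxy.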